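Cyclohexyl in place of 3-methoxyphenyl on compound 2

The source may hold more compounds than are shown below. What is called first, only, known or untested is meant among the compounds shown, and "the series" means these compounds.

In a functional assay on A-375 cells (Homo sapiens) for antiproliferative activity, read by MTT assay, with a stated time of 72 h (a higher number here means a weaker inhibitor, a lower number a stronger inhibitor), compound 1 `COc1ncc(-c2ccc3c(c2)N(c2ccccc2)C(=O)CO3)cc1NS(=O)(=O)c1ccc(F)cc1` gives 15200 nM as a measured number. Compound 2 `COc1cccc(N2C(=O)COc3ccc(-c4cccc(NS(=O)(=O)c5ccc(F)cc5)c4)cc32)c1` reads > 40000 nM in this assay and this is a limit of the assay, not a number. Compound 3 `O=C1COc2ccc(-c3cccc(NS(=O)(=O)c4ccc(F)cc4)c3)cc2N1C1CCCCC1` carries cyclohexyl in place of 3-methoxyphenyl on an amide-type nitrogen in a ring with the rest of compound 2 unchanged. Among the measured compounds shown here, no measured step covers this change, so no shift beyond the scatter is expected in this assay and the estimated step of an at least 1.1-fold lower number from compound 2 to compound 3 (0.05 log units; that floor lies within the scatter) stays small. Compound 3 is expected at 35000 nM with an estimated range from 15000 nM to 60000 nM in this measurement.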

Compound 3, half-maximal inhibitory concentration: 23800 nM
Beside the measured number, compound 3's estimate is 1.5-fold (0.17 log units) above it, and the stated range covers the measured number.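

An aromatic ring on this amide-type nitrogen is not needed for a readable value in this assay: compound 3, with cyclohexyl, gives 23800 nM. Cyclohexyl in place of 3-methoxyphenyl gives an at least 1.6-fold lower number from compound 2 to compound 3 (0.22 log units; that floor lies within the scatter). That step is only a floor, and its true size stays unknown: the limit of > 40000 nM in this assay, at which 1 of the 3 values shown sits.

Still open, going by these compounds, is whether methyl, cyclopropyl or a chain ending in an amine on this nitrogen would move the number beyond the scatter. Compound 1 differs from compound 2 and compound 3 in more than one place, so it gives no separate reading on this nitrogen.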